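A few compounds are considered here, and "the series" means these few. Any claim that something is new, unique, unknown or untested is made for them only; others in the source may bear on it.

Working notes on the series. Compounds 1, 2 and 3 share one core and differ only in the group on an amine nitrogen in a ring: compound 1 `COc1cc(Cc2cnc(/N=C3\C(=O)N(CN4CCN(Cc5ccccc5)CC4)c4ccc(Cl)cc43)nc2N)cc(OC)c1OC` carries benzyl, compound 2 `COc1cc(Cc2cnc(/N=C3\C(=O)N(CN4CCN(c5cccc(Cl)c5)CC4)c4ccc(Cl)cc43)nc2N)cc(OC)c1OC` carries 3-chlorophenyl, and compound 3 `COc1cc(Cc2cnc(/N=C3\C(=O)N(CN4CCN(c5ccccn5)CC4)c4ccc(Cl)cc43)nc2N)cc(OC)c1OC` carries pyridin-2-yl. In an ADME assay on MT4 cells (Homo sapiens) for cytotoxicity, read by MTT assay, with a stated time of 5 days (a lower number here means that less compound is tolerated, a higher number that more compound is tolerated), compound 1 gives 36.1 ug/mL, compound 2 gives 39.2 ug/mL and compound 3 gives 39.2 ug/mL. Compound 3 thus sits level with compound 2 at the digits reported and within the scatter of compound 1; none of the three is separated from the others.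

The measured steps are a 1.1-fold higher number from compound 1 to compound 2 (0.04 log units; within the scatter), a 1.1-fold higher number from compound 1 to compound 3 (0.04 log units; within the scatter) and no change at the digits printed from compound 2 to compound 3 (within the scatter). Each swap of the aryl or benzyl group at this ring nitrogen left the read-out unmoved.

Compound 4 `COc1cccc(N2CCN(CN3C(=O)/C(=N\c4ncc(Cc5cc(OC)c(OC)c(OC)c5)c(N)n4)c4cc(Cl)ccc43)CC2)c1` continues this pattern: 3-methoxyphenyl in place of pyridin-2-yl on an amine nitrogen in a ring. All three steps at the same place were within the scatter, so no shift beyond the scatter is expected here either. For compound 4 in this assay the estimated value is 38 ug/mL, with a range from 25 ug/mL to 58 ug/mL. The expected step is a 1.0-fold lower number from compound 3 to compound 4 (0.01 log units; within the scatter).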

Compound 4, half-maximal cytotoxic concentration: 32.6 ug/mL
Estimate against measurement, compound 4: 1.2-fold (0.07 log units) above; the range from low to high includes it.
By their numbers in this assay, from the lowest: compounds 4, 1, 2 and 3 (each within the scatter of the next).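

Swapping pyridin-2-yl for 3-methoxyphenyl brings a methoxy-bearing, carbon-only aromatic ring onto this amine nitrogen without separating compound 4 from the earlier compounds in this assay (a 1.2-fold lower number from compound 3 to compound 4 (0.08 log units; within the scatter)), and the same holds against the benzyl group (a 1.1-fold lower number from compound 1 to compound 4 (0.04 log units; within the scatter)). The comparison with the 3-chlorophenyl group adds the first change made on the aromatic ring itself rather than a swap of the whole group: methoxy in place of chloro on an aromatic carbon also stays within the scatter (a 1.2-fold lower number from compound 2 to compound 4 (0.08 log units; within the scatter)). No measured data bear on why these numbers stay together.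

Going by these compounds, all four groups at this nitrogen carry an aromatic ring, so a simple alkyl chain, a carboxylic acid or a primary amine here remains open. Whether any such group would separate from these four in this assay cannot be told from these compounds.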